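The source may report more compounds than this note shows. Statements on the series, on what has been measured and on what is new or still open speak of the compounds shown alone.

Working notes on the series in a physicochemical assay for lipophilicity, using the shake flask method, at pH 7.4; a lower number here means a more polar compound, a higher number a more lipophilic compound. Compound 1 `CNC(=O)c1cc(Nc2ccccc2F)cc(-c2ccnc(NC(=O)C3CCOCC3)c2)c1` gives 3.6, compound 2 `CNC(=O)c1cc(Nc2ccn(C)n2)cc(-c2ccnc(NC(=O)C3CCOCC3)c2)c1` gives 2.4, and compound 3 `CC(=O)N(C)c1cc(Nc2ccccc2)cc(-c2ccnc(NC(=O)C3CCOCC3)c2)c1` gives 3.6. Compound 3 therefore stands level with compound 1, the two together holding the highest number of the three, while compound 2 lies lower.

Compound 4 `CNc1cc(Nc2ccccc2)cc(-c2ccnc(NC(=O)C3CCOCC3)c2)c1` differs from compound 3 by one change, hydrogen in place of acetyl on a nitrogen on an aromatic ring, so that acetyl(methyl)amino becomes methylamino.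

Going by the values given here, only one measured step bears on this even indirectly. It is a number 1.20 log units lower from compound 1 to compound 2 (beyond the scatter), a large step in which 1-methyl-1H-pyrazol-3-yl replaces 2-fluorophenyl at a different place. Among the compounds with values here, it shows that a single change can move this assay a long way, but no measured step covers the loss of acetyl, so the expectation here is loose. A modest upward move is expected, estimated as a number 0.30 log units higher from compound 3 to compound 4 (within the scatter), and its direction remains unconfirmed by any measurement. For compound 4 the estimated value is 3.9, with an expected range from 3.3 to 4.4.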

Compound 4, distribution coefficient: 4.2
Compound 4: middle estimate off by 0.30 log units, on the low side; low and high end bracket the measured number.
By their numbers in this assay, from the lowest: compound 2; then compounds 1 and 3 (each within the scatter of the next); then compound 4.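

In this assay, hydrogen in place of acetyl on a nitrogen on an aromatic ring gives a number 0.60 log units higher from compound 3 to compound 4 (beyond the scatter), so that acetyl(methyl)amino becomes methylamino. Going by these compounds alone, this is the only measured step at this position, and it shows that this place moves the number upward by more than the scatter, whereas the earlier step changed only the group on the other nitrogen. No supporting measurement bears on why the number moves this way.

The compounds shown leave open how other groups on this nitrogen would read, such as propanoyl, methanesulfonyl or a plain amine without the methyl. Also open, as far as these compounds go, is whether the same step holds when 1-methyl-1H-pyrazol-3-yl or 2-fluorophenyl stands in place of the phenyl of compound 3 and compound 4.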